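A few compounds are considered here, and "the series" means these few. Any claim that something is new, unique, unknown or untested is made for them only; others in the source may bear on it.

In a functional assay on HT-29 cells (Homo sapiens) for cytotoxicity, read by MTT assay, with a stated time of 24 h, tested at 16 ug/mL (a higher number here means a stronger effect of the compound at the concentration tested, a lower number a weaker effect), compound 1 `Cn1c(-c2ccc(NC(=O)CCl)cc2)nc(-c2ccccc2)c1-c1ccccc1` gives 23.7%, compound 2 `Cn1c(-c2ccc(NC(=O)CSc3nc4cc(Cl)ccc4o3)cc2)nc(-c2ccccc2)c1-c1ccccc1` gives 42.5% and compound 3 `CCN1CCN(CC(=O)Nc2ccc(-c3nc(-c4ccccc4)c(-c4ccccc4)n3C)cc2)CC1` gives 28.4%. Of the three numbers, compound 3 sits within the scatter of compound 1, while a number 14.1 percentage points lower from compound 2 to compound 3 (beyond the scatter). Compound 4 `Cn1c(-c2ccc(NC(=O)CN3CCN(c4ccccc4)CC3)cc2)nc(-c2ccccc2)c1-c1ccccc1` differs from compound 3 by phenyl in place of ethyl on an amine nitrogen in a ring. For the measured compounds named here, no measured step alters a group on the amine nitrogen in the ring; the steps in hand, a number 18.8 percentage points higher from compound 1 to compound 2 (beyond the scatter) and a number 4.7 percentage points higher from compound 1 to compound 3 (within the scatter), both change the group on the saturated chain carbon bound to the carbonyl carbon, so they do not bear directly on this change and serve only to show the spread of the series. For compound 4 in this assay the expected step is therefore a number 1.6 percentage points higher from compound 3 to compound 4 (within the scatter), not beyond the scatter. Compound 4 is estimated at 30%, within 18% to 44%.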

Compound 4, a percentage reported as activity, at one concentration (the size of the read-out at that concentration, not a potency): 55.4%
Beside the measured number, compound 4's estimate is 25.4 percentage points below it; measured number outside the range, above it.
By their numbers in this assay, from the lowest: compounds 1 and 3 (each within the scatter of the next); then compound 2; then compound 4.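

In this assay the amine nitrogen in the ring proves a sensitive place, with phenyl in place of ethyl giving a number 27 percentage points higher from compound 3 to compound 4 (beyond the scatter) in this series. Compound 4 also clears the others, with a number 12.9 percentage points higher from compound 2 to compound 4 (beyond the scatter) and a number 31.7 percentage points higher from compound 1 to compound 4 (beyond the scatter) so that 4-phenylpiperazin-1-yl gives the highest number of the four. No evidence at hand accounts for these steps.

As far as these compounds go, whether the gain requires phenyl itself remains open, as benzyl, cyclohexyl or 4-chlorophenyl on that nitrogen would test. Potency also remains open, since the read-out comes from one concentration.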